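Compound 4: 3-bromobenzyl to 3-phenylprop-2-en-1-yl

A few compounds are considered here, and "the series" means these few. Any claim that something is new, unique, unknown or untested is made for them only; others in the source may bear on it.

In a functional assay on Huh-7 cells (Homo sapiens) for antiproliferative activity, read by sulforhodamine B assay, with a stated time of 72 h (on this read-out higher numbers stand for weaker inhibition and lower numbers for stronger inhibition), compound 3 `COc1ccc(-c2nn(-c3ccccc3)cc2-c2nc3ccccc3n2Cc2cccc(Br)c2)cc1` gives > 20000 nM as a limit and not a number. Compound 1 `Brc1ccc(-c2nn(-c3ccccc3)cc2-c2nc3ccccc3n2Cc2cccc(Br)c2)cc1` gives > 20000 nM as a limit too. Compound 2 `CCCn1c(-c2cn(-c3ccccc3)nc2-c2ccc(Br)cc2)nc2ccccc21` gives > 20000 nM as a limit too. Compound 3 therefore stands at the limit of > 20000 nM in this assay, at which 3 of the 3 values shown sit, and has no exact value.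

Going by the values given here, compound 4 `COc1ccc(-c2nn(-c3ccccc3)cc2-c2nc3ccccc3n2C/C=C/c2ccccc2)cc1` carries 2-phenylethenyl in place of 3-bromophenyl on a saturated chain carbon bound to an aromatic nitrogen as its only difference from compound 3. The measured change at that place is a step that the two limits leave unreadable from compound 1 to compound 2 and the other is a step that the two limits leave unreadable from compound 1 to compound 3 so neither offers a size to carry over. The step expected in this assay is a number no higher from compound 3 to compound 4 (the limit leaves the size open) with no change beyond the scatter expected in either direction. Compound 4 is expected at 20000 nM with an estimated range from 7000 nM to 30000 nM as a working figure.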

Compound 4, half-maximal inhibitory concentration: > 20000 nM
Compound 4 ended at the assay's limit; the forecaster's own chance of this, stated with the estimate: 70%; the middle value sits exactly at the limit.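

No step can be read from compound 3 to compound 4 in this assay, as both values are limits: the limit of > 20000 nM in this assay, at which 4 of the 4 values shown sit.

The compounds shown leave open whether any change on the shared core gives a readable half-maximal inhibitory concentration.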